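A few compounds are considered here, and "the series" means these few. Any claim that something is new, unique, unknown or untested is made for them only; others in the source may bear on it.

Of the compounds shown here, three have been measured in a functional assay on EKVX cells (Homo sapiens) for inhibition, read by sulforhodamine B assay, with a stated time of 48 h, tested at 10 uM; a lower number here means less inhibition, a higher number more inhibition at the concentration tested (going by the name of the read-out). Compound 1 `Brc1cn2ccnc2c(-c2ccc3ncn(C4CCCCC4)c3c2)n1` gives 12%, compound 2 `Brc1ccc(-c2cn3ccnc3c(-c3ccc4ncn(C5CCCCC5)c4c3)n2)cc1` gives 16.2%, and compound 3 `CCc1ccc(-c2cn3ccnc3c(-c3ccc4ncn(Cc5ccccc5)c4c3)n2)cc1` gives 39.7%, the highest of the three; the gap from compound 2 to compound 3 and from compound 1 to compound 3 is beyond the scatter. Among the compounds with values here, the only step between measured neighbours, a number 4.2 percentage points higher from compound 1 to compound 2 (within the scatter), replaces a different group and does not bear on the change now considered. Compound 4 `Cc1cccc(-c2cn3ccnc3c(-c3ccc4ncn(Cc5ccccc5)c4c3)n2)c1` differs from compound 3 by 3-methylphenyl in place of 4-ethylphenyl on an aromatic carbon. Within the data shown here, with no measured step of this kind, the change is expected to bring no step beyond the scatter, a number 5.7 percentage points lower from compound 3 to compound 4 (within the scatter). Compound 4 is therefore estimated at 34%, within 16% to 52%.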

Compound 4, a percentage reported as inhibition, at one concentration (the size of the read-out at that concentration, not a potency): 22.3%
The estimate for compound 4 lay 11.7 percentage points above the measured number; the measured number falls inside the stated range.
By their numbers in this assay, from the lowest: compounds 1, 2 and 4 (each within the scatter of the next, the first and the last beyond it); then compound 3.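

In this assay, the aryl group at this position matters: 3-methylphenyl in place of 4-ethylphenyl gives a number 17.4 percentage points lower from compound 3 to compound 4 (beyond the scatter), the first step at this position among the compounds shown. The swap changes both the size of the alkyl group and its place on the phenyl ring, so this single step cannot separate the two. Nothing measured here accounts for the drop.

On these data alone, whether 4-methylphenyl or 3-ethylphenyl would retain the inhibition of compound 3 remains open. So does the effect of an amine or a carboxylic acid on that phenyl ring.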